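The source may hold more compounds than are shown below. What is called first, only, known or untested is meant among the compounds shown, and "the series" means these compounds.

Measured so far in a functional assay on CHO cells for activation of adenosine receptor A2b (Homo sapiens), read by cAMP accumulation; on this read-out lower numbers stand for an effect already at smaller amounts and higher numbers for an effect only at larger amounts of compound:
- compound 1 `CCNC(=O)[C@H]1O[C@@H](n2cnc3c(NNC(=O)c4ccccc4)nc(Cl)nc32)[C@H](O)[C@@H]1O`: compound 1 reaches only the assay limit, > 5000 nM.
- compound 2 `CCNC(=O)[C@H]1O[C@@H](n2cnc3c(NNC(=O)c4cccs4)nc(Cl)nc32)[C@H](O)[C@@H]1O`: 200 nM.
- compound 3 `CCNC(=O)[C@H]1O[C@@H](n2cnc3c(NNC(=O)c4ccc[nH]4)nc(Cl)nc32)[C@H](O)[C@@H]1O`: 359 nM.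

Compound 3 holds the highest of the two numbers; compound 2 is nearest, a 1.8-fold higher number from compound 2 to compound 3 (0.25 log units; within the scatter). Compound 4 `CCNC(=O)[C@H]1O[C@@H](n2cnc3c(NNC(=O)c4cc(C)on4)nc(Cl)nc32)[C@H](O)[C@@H]1O` is not yet measured. The change is 5-methyl-1,2-oxazol-3-yl in place of 1H-pyrrol-2-yl on a carbonyl carbon. For the measured compounds named here, the steps that bear on the five-membered ring at the carbonyl are an at least 25-fold lower number from compound 1 to compound 2 (1.39 log units; beyond the scatter) and an at least 13-fold lower number from compound 1 to compound 3 (1.14 log units; beyond the scatter), both large and both away from a limit (the limit of > 5000 nM in this assay, at which 1 of the 3 values shown sits); between the two five-membered rings themselves the step is a 1.8-fold higher number from compound 2 to compound 3 (0.25 log units; within the scatter). No ring with two hetero atoms has been measured in this assay. For compound 4 the number in this assay is therefore expected to stay near that of compound 3, estimated at 500 nM (range 150 nM to 2500 nM), meaning an expected step of a 1.4-fold higher number from compound 3 to compound 4 (0.14 log units; within the scatter).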

Compound 4, half-maximal effective concentration: > 5000 nM
Compound 4 gave a limit, no number; the forecaster's own chance of this, stated with the estimate: 10%; at least 10-fold (1.00 log units) between middle value and limit.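

In this assay a five-membered aromatic ring on the carbonyl carbon does not by itself carry the effect: 5-methyl-1,2-oxazol-3-yl in place of 1H-pyrrol-2-yl gives an at least 13-fold higher number from compound 3 to compound 4 (1.14 log units; beyond the scatter) and in place of thiophen-2-yl gives an at least 25-fold higher number from compound 2 to compound 4 (1.39 log units; beyond the scatter) on the same carbonyl carbon. Compound 4 gives > 5000 nM as a limit of the assay and not a number. The step from compound 1 to compound 4 cannot be read: the limit of > 5000 nM in this assay, at which 2 of the 4 values shown sit.

The compounds shown do not separate the methyl from the 1,2-oxazole ring. Going by these compounds, whether 1,2-oxazol-3-yl without the methyl, furan-2-yl or 1,3-thiazol-2-yl would stay with compound 2 and compound 3 or go to the limit remains open.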